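A methyl to bromo swap on compound 2

The compounds below may be only part of what the source reports. "The series", "measured", "known", "first", "only" and "open" are said of these compounds alone.

Of the compounds shown here, two have so far been tested in a functional assay on PC-3 cells (Homo sapiens) for antiproliferative activity, read by MTT assay, with a stated time of 72 h; a higher number here means a weaker inhibitor, a lower number a stronger inhibitor. Compound 1 (`CCOC(=O)c1csc2nc(CN3CCN(Cc4ccccc4)CC3)c(-c3ccc(Br)cc3)n12`) gives 56400 nM and compound 2 (`Cc1ccc(-c2c(CN3CCCCC3)nc3scc(C(=O)O)n23)cc1`) gives 16600 nM, the lower of the two numbers. The gap between them lies beyond the usual scatter, so compound 2 is the stronger inhibitor of the pair.

Compound 3 (`O=C(O)c1csc2nc(CN3CCCCC3)c(-c3ccc(Br)cc3)n12`) departs from compound 2 in one place (bromo in place of methyl on an aromatic carbon). It has bromo in place of methyl on an aromatic carbon, para to a large group, so 4-methylphenyl becomes 4-bromophenyl.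

For the measured compounds named here, no two measured compounds differ in only one place, so the data offer no direct reading of this change. The expectation therefore rests on compound 2 (16600 nM) and on the small size of the structural change. The estimated move is a 1.1-fold lower number from compound 2 to compound 3 (0.04 log units; within the scatter) and is expected to stay within the scatter in this assay, with no firm direction. Compound 3 is estimated at 15000 nM, with an expected range of (6000 nM to 40000 nM).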

Compound 3, half-maximal inhibitory concentration: > 100000 nM
Compound 3 ended at the assay's limit (the forecaster's own chance of this, stated with the estimate: 10%); at least 6.6-fold (0.82 log units) between middle value and limit.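

In this assay compound 3 gives > 100000 nM, which is a limit of the assay and not a number. For the compounds shown here, this is the first direct reading of a single change: exchanging methyl for bromo on an aromatic carbon, para to a large group, turns 4-methylphenyl into 4-bromophenyl and gives an at least 6.0-fold higher number from compound 2 to compound 3 (0.77 log units; beyond the scatter), so one heavy atom at this position is enough to move the result beyond the scatter. The full size of the step cannot be read, and the bound on it is set by the top of the assay's range: the limit of > 100000 nM in this assay, at which 1 of the 3 values shown sits.

The compounds shown leave open how other groups at this position would read, such as a chloro or a methoxy group, and so whether methyl is tolerated there as a special case or bromo is the exception. They also leave open whether the same exchange of methyl for bromo would give a similar step with a primary amide in place of the carboxylic acid on the shared core.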